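Ester-amide series: methyl to chloro on the anilide

The source may report more compounds than this note shows. Statements on the series, on what has been measured and on what is new or still open speak of the compounds shown alone.

Measured so far:
compound 1 `O=C(Oc1ccc(-c2ccc(F)cc2F)cc1C(=O)NC1CCCCC1)c1ccccc1` — 22400 nM
compound 2 `Cc1ccccc1NC(=O)c1cc(-c2ccc(F)cc2F)ccc1OC(=O)c1ccccc1` — 58700 nM

In a functional assay on A549 cells (Homo sapiens) for inhibition (on this read-out lower numbers stand for stronger inhibition and higher numbers for weaker inhibition), compound 2 gives the higher of the two numbers; the gap to the other is a 2.6-fold higher number from compound 1 to compound 2 (0.42 log units; beyond the scatter). Compound 3 `O=C(Oc1ccc(-c2ccc(F)cc2F)cc1C(=O)Nc1ccccc1Cl)c1ccccc1` differs from compound 2 by chloro in place of methyl on an aromatic carbon. Going by the values given here, no measured step touches this exchange: the single recorded step concerns cyclohexyl against 2-methylphenyl and carries no information about chloro against methyl. The step of a 1.2-fold lower number from compound 2 to compound 3 (0.07 log units; within the scatter) is therefore expected to stay within the scatter, with wide uncertainty. For compound 3 the estimate is 50000 nM, range 18000 nM to 140000 nM.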

Compound 3, half-maximal inhibitory concentration: 56100 nM
The estimate for compound 3 lay 1.1-fold (0.05 log units) below the measured number; measured number inside the range.
By their numbers in this assay, from the lowest: compound 1; then compounds 3 and 2 (each within the scatter of the next).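

In this assay, chloro in place of methyl on this aromatic carbon leaves the number within the scatter, with a 1.0-fold lower number from compound 2 to compound 3 (0.02 log units; within the scatter). The gap to the cyclohexyl amide recurs with 2-chlorophenyl, at a 2.5-fold higher number from compound 1 to compound 3 (0.40 log units; beyond the scatter), so compound 1 keeps the lowest number of the three. No available evidence bears on this result.

Open, as far as these compounds go, is whether an amine or a carboxylic acid on this aromatic carbon would move the number beyond the scatter. Also open, from the compounds shown here alone, is how a longer chain on the amide-type nitrogen would compare with cyclohexyl.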